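Benzyloxy Added to Compound 1: Expected Cytotoxicity

This account rests on a few compounds, and the source may have more. Where it says the series, first, only, none or still open, it means among the compounds named here.

Compound 1 `COc1ccc(/C=C/C(=O)c2c(C)cc(O)c(C(=O)/C=C/c3ccc(OC)c(OC)c3)c2-c2ccccc2)cc1OC` was tested in an ADME assay on HEK293 cells (Homo sapiens) for cytotoxicity, read by MTT assay, with a stated time of 24 h (a lower number here means a stronger inhibitor, a higher number a weaker inhibitor), and in that test compound 1 gives "not active" (no number reported), so no single number describes where it stands. A related compound, compound 2 `Cc1cc(O)c(C(=O)/C=C/c2ccc(OCc3ccccc3)cc2)c(-c2ccc(Br)cc2)c1C(=O)/C=C/c1ccc(OCc2ccccc2)cc1`, carries benzyloxy groups and a bromine on its rings, and in this assay compound 2 gives 25000 nM, a weak effect. Compound 3 `COc1ccc(/C=C/C(=O)c2c(C)cc(O)c(C(=O)/C=C/c3ccc(OC)c(OC)c3)c2-c2ccc(OCc3ccccc3)cc2)cc1OC` has not yet been measured. It differs from compound 1 by benzyloxy in place of hydrogen on an aromatic carbon; in words, benzyloxy in place of hydrogen on an aromatic carbon. Among the compounds with values here, no step between two measured compounds is available here, so the size of the change from compound 1 to compound 3 in this assay can only be expected: a move toward a measurable but still weak effect, possibly no larger than the usual scatter. Compound 3 is expected to give about 40000 nM, with a likely range from 15000 nM to 100000 nM.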

Compound 3, half-maximal inhibitory concentration: 30000 nM
Estimate against measurement, compound 3: 1.3-fold (0.12 log units) above; the measured number falls inside the stated range.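

In this assay, within the data shown here, compound 1 gives "not active" (no number reported) and compound 3 gives 30000 nM, so no step from compound 1 to compound 3 can be read. On these data alone, how far benzyloxy in place of hydrogen shifts the cytotoxicity stays open. No measured evidence bears on this result.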